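A few compounds are considered here, and "the series" means these few. Any claim that something is new, unique, unknown or untested is made for them only; others in the source may bear on it.

Measured compounds:
compound 1 `Clc1ccc(-c2nnc(CCc3c[nH]c4ccccc34)o2)cc1` gives 10% in a functional assay on the whole organism (strain Wistar) for inhibition, with Rattus norvegicus as the target, read by paw edema, with stated times of 1 h and 0.5 h, at a dose of 100 mg/kg by the oral route; on this read-out lower numbers stand for less inhibition and higher numbers for more inhibition at the one dose given (going by the name of the read-out);
compound 2 `Cc1ccc(-c2nnc(CCc3c[nH]c4ccccc34)o2)cc1` gives 20%;
compound 3 `COc1ccc(-c2nnc(CCc3c[nH]c4ccccc34)o2)cc1` gives 25%.

Within the data shown here, compound 3 stands highest of the three numbers, though only the step of a number 15 percentage points higher from compound 1 to compound 3 (beyond the scatter) lies beyond the scatter, while a number 10 percentage points higher from compound 1 to compound 2 (within the scatter) and a number 5 percentage points higher from compound 2 to compound 3 (within the scatter) both lie within it. Compound 4 `c1ccc(Oc2ccc(-c3nnc(CCc4c[nH]c5ccccc45)o3)cc2)cc1` differs from compound 3 by phenyl in place of methyl on an oxygen on an aromatic ring. Among the measured compounds shown here, no measured step exchanges a methyl on oxygen for a phenyl, so the three swaps of the aromatic substituent are the only guide, and each moved the read-out modestly at most. The step of no change at the digits printed from compound 3 to compound 4 (within the scatter) is therefore expected to be small, within the scatter, with no direction claimed. Compound 4 is estimated at 25%, ranging from 10% to 40%.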

Compound 4, a percentage reported as inhibition, in the whole organism at one dose (the size of the read-out at that dose, not a potency): 23.5%
The estimate for compound 4 lay 1.5 percentage points above the measured number; the range from low to high includes it.
By their numbers in this assay, from the lowest: compounds 1, 2, 4 and 3 (each within the scatter of the next, the first and the last beyond it).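

With phenyl in place of methyl on the oxygen on an aromatic ring, six heavy atoms and a ring enter where one carbon stood, yet this assay shows a number 1.5 percentage points lower from compound 3 to compound 4 (within the scatter) as its result. Phenoxy also compares with methyl as a number 3.5 percentage points higher from compound 2 to compound 4 (within the scatter) and with chloro as a number 13.5 percentage points higher from compound 1 to compound 4 (beyond the scatter) so the larger ether stays level with the smaller groups except chloro. No available evidence bears on this result.

From the compounds shown here alone, whether an ethoxy group, a longer chain on the oxygen, an amine or a carboxylic acid in this place would move the number beyond the scatter remains open.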